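Swapping fluoro for chloro on a thiazolidinone cytotoxicity probe

The source may hold more compounds than are shown below. What is called first, only, known or untested is meant among the compounds shown, and "the series" means these compounds.

Compound 1 `O=C1CSC(c2ccc(O)cc2)N1CCN1CCCCC1` is measured in an ADME assay on Vero cells (Chlorocebus sabaeus) for cytotoxicity, read by neutral red uptake, tested at 98 ug/mL (a higher number here means a weaker effect of the compound at the concentration tested, a lower number a stronger effect), where compound 1 gives 94%. Compound 2 `O=C1CSC(c2ccc(F)cc2)N1CCN1CCCCC1` differs by carrying fluoro in place of hydroxy on an aromatic carbon; in this assay compound 2 gives 87%. The step of a number 7 percentage points lower from compound 1 to compound 2 (within the scatter) shows that these two numbers sit within the usual scatter of each other, so compound 2 stands alongside compound 1 rather than apart from it.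

Compound 3 `O=C1CSC(c2ccc(Cl)cc2)N1CCN1CCCCC1` is not yet measured. It differs from compound 2 by chloro in place of fluoro on an aromatic carbon. For the measured compounds named here, the only measured step, a number 7 percentage points lower from compound 1 to compound 2 (within the scatter), changed the same position and stayed within the scatter, but it does not involve chloro, so no direct precedent exists. The step of a number 3 percentage points lower from compound 2 to compound 3 (within the scatter) is therefore expected to stay within the scatter. Compound 3 is estimated to give 84%, between 62% and 98%.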

Compound 3, a percentage reported as activity, at one concentration (the size of the read-out at that concentration, not a potency): 74%
The estimate for compound 3 lay 10 percentage points above the measured number; the range from low to high includes it.
By their numbers in this assay, from the lowest: compound 3; then compounds 2 and 1 (each within the scatter of the next).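

On this aromatic carbon, para to a large group, the change to chloro gives a number 13 percentage points lower from compound 2 to compound 3 (beyond the scatter) and a number 20 percentage points lower from compound 1 to compound 3 (beyond the scatter) in this assay while the earlier change from hydroxy to fluoro stayed within the scatter. The group held here can therefore alter the read-out, and compound 3 stands apart from the other two with the stronger effect at the concentration tested. Nothing available explains why chloro parts from fluoro in this way.

Going by these compounds, whether this shift is particular to chloro remains open, since bromo, methyl and trifluoromethyl on the same carbon would each test that in a different way. It is also unknown how an amine or a carboxylic acid at this place would read, so one chloro compound cannot yet define what the position tolerates.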